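A Bromine Added to the Shared Core: Tolerance Expected to Hold

The compounds below may be only part of what the source reports. "The series", "measured", "known", "first", "only" and "open" are said of these compounds alone.

Compound 2 `N#Cc1ccc(Nc2nccc(Oc3ccc4cc(C#N)ccc4c3)n2)cc1` was examined in an ADME assay on MT4 cells (Homo sapiens) for cytotoxicity, read by MTT assay, with a stated time of 4 days; a lower number here means that less compound is tolerated, a higher number that more compound is tolerated. In this assay compound 2 gives > 68800 nM, which is a limit of the assay rather than a measured number. Compound 1 `COc1cc2cc(C#N)ccc2cc1Oc1ccnc(Nc2ccc(C#N)cc2)n1` also reaches only a limit: in this assay compound 1 gives > 318000 nM. Among the compounds with values here, the single measured step, a step that the two limits leave unreadable from compound 1 to compound 2, cannot be sized; both values are limits, the limit of > 318000 nM in this assay, at which 1 of the 2 values shown sits, and (the limit of > 68800 nM in this assay, at which 1 of the 2 values shown sits).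

Compound 3 `N#Cc1ccc(Nc2nccc(Oc3cc4ccc(C#N)cc4cc3Br)n2)cc1` differs from compound 2 by bromo in place of hydrogen on an aromatic carbon. Within the data shown here, no measured step speaks to adding a bromo at such a place, and the one step on record is unreadable, so nothing points to a shift beyond the usual scatter in this assay. Compound 3 is therefore expected to tolerate roughly the same amount, most likely again as a limit, with an estimated 70000 nM, ranging from 25000 nM to 300000 nM. The estimated step that the limit leaves unreadable from compound 2 to compound 3 is expected to be small.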

Compound 3, half-maximal cytotoxic concentration: > 56500 nM
Compound 3 was reported as a limit; the forecaster's own chance of this, stated with the estimate: 80%; the middle value does not contradict the limit.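

In this assay compound 3 gives > 56500 nM, which is a limit of the assay and not a number. Within the data shown here, with compound 1, compound 2 and compound 3 all at limits, no step among them can be read. The compounds shown leave open whether bromo in place of hydrogen on an aromatic carbon changes tolerance at all.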